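This account rests on a few compounds, and the source may have more. Where it says the series, first, only, none or still open, it means among the compounds named here.

Compound 1 `Cc1nc(N)c2c(-c3cccs3)cn([C@@H]3O[C@H](CO)[C@@H](O)[C@H]3O)c2n1` and compound 2 `Cc1nc(N)c2c(-c3ccco3)cn([C@@H]3O[C@H](CO)[C@@H](O)[C@H]3O)c2n1` share one core and differ only in the ring that hangs from one aromatic carbon. In an ADME assay on MRC5 cells (Homo sapiens), read by MTT assay, with a stated time of 72 h (a higher number here means a weaker inhibitor, a lower number a stronger inhibitor), compound 1 gives > 100000 nM, which is a limit of the assay and not a number. In this assay compound 2 gives > 100000 nM, again a limit and not a number. The step that the two limits leave unreadable from compound 1 to compound 2 therefore cannot be read, and compound 2 stands only at the limit, the point at which both shown values sit (the limit of > 100000 nM in this assay, at which 2 of the 2 values shown sit). Compound 3 `Cc1nc(N)c2c(I)cn([C@@H]3O[C@H](CO)[C@@H](O)[C@H]3O)c2n1` carries a further change at that same carbon: iodo in place of furan-2-yl on an aromatic carbon. Going by the values given here, the only measured step that bears on it is unreadable, so it gives neither a direction nor a size. The expected step is a number no higher from compound 2 to compound 3 (the limit leaves the size open), nothing beyond the scatter. Compound 3 is therefore expected to stay at the limit, with an estimate of 100000 nM in a range from 30000 nM to 300000 nM.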

Compound 3, half-maximal inhibitory concentration: 85800 nM
Compound 3: the middle estimate sits 1.2-fold (0.07 log units) above what was measured; low and high end bracket the measured number.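

With iodo on this aromatic carbon, compound 3 gives the only true number shown in this assay, so the position no longer reads as a limit alone. Measured against the furan-2-yl group, the change is an at least 1.1-fold lower number from compound 2 to compound 3 (0.06 log units; that floor lies within the scatter); measured against the thiophen-2-yl group, it is an at least 1.1-fold lower number from compound 1 to compound 3 (0.06 log units; that floor lies within the scatter). Both steps give only a floor, and how far they really reach cannot be read, because the two compounds that carry a ring at this carbon stay at a limit: the limit of > 100000 nM in this assay, at which 2 of the 3 values shown sit.

From the compounds shown here alone, whether any real difference belongs to iodo itself or to the loss of the five-membered aromatic ring stays open. Going by these compounds, what an amine, a carboxylic acid or a longer chain on this carbon would give in this assay also stays open.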